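A few compounds are considered here, and "the series" means these few. Any claim that something is new, unique, unknown or untested is made for them only; others in the source may bear on it.

Measured in a functional assay on NB-4 cells (Homo sapiens) for cytotoxicity, read by CCK-8 assay, with a stated time of 24 h; a higher number here means a weaker inhibitor, a lower number a stronger inhibitor:
- Compound 1 `C=CC(=O)N1C(=O)CC(c2ccc(C)cc2)Sc2ccccc21`: 37300 nM
- Compound 2 `C=CC(=O)N1C(=O)CCSc2ccccc21`: 22400 nM

Compound 2 has only compound 1 to be compared with, and their two values lie within the scatter of each other, so it holds no clear rank. Compound 3 `C=CC(=O)N1C(=O)CC(c2cccc(Cl)c2)Sc2ccccc21` comes from compound 2 by a single change, 3-chlorophenyl in place of hydrogen on a saturated ring carbon.

Among the compounds with values here, one measured step bears on this change. It exchanges 4-methylphenyl for hydrogen on a saturated ring carbon and gives a 1.7-fold lower number from compound 1 to compound 2 (0.22 log units; within the scatter). Read in reverse, it suggests that adding a substituted phenyl ring need not move the number beyond the scatter. Within the data shown here, no measured compound carries 3-chlorophenyl, so the step is only an indirect guide, and the range must stay wide. In this assay, no step beyond the scatter is therefore expected, and compound 3 should fall close to compound 1 at 37300 nM.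

The expected change is a 1.3-fold higher number from compound 2 to compound 3 (0.13 log units; within the scatter). For compound 3, the estimated value is 30000 nM, with an expected range of 12000 nM to 70000 nM.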

Compound 3, half-maximal inhibitory concentration: 31700 nM
Beside the measured number, compound 3's estimate is 1.1-fold (0.02 log units) below it, and the stated range covers the measured number.
By their numbers in this assay, from the lowest: compounds 2, 3 and 1 (each within the scatter of the next).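

In this assay the saturated ring carbon next to the ring sulfur now has a second substituted phenyl ring on record: 3-chlorophenyl in place of hydrogen gives a 1.4-fold higher number from compound 2 to compound 3 (0.15 log units; within the scatter) and, like 4-methylphenyl, stays within the scatter of the compound with hydrogen at this position. Exchanging one ring for the other gives a 1.2-fold lower number from compound 1 to compound 3 (0.07 log units; within the scatter), so across the three compounds neither the substituent on the phenyl ring, chlorine or methyl, nor its location on that ring separates the values, although the comparison covers only these two rings. Nothing available accounts for why the values stay so close together.

The compounds shown leave open whether an amine, a carboxylic acid or a longer alkyl chain on this carbon, in place of a phenyl ring, would take the number beyond the scatter. All three compounds also carry the vinylcarbonyl group, so the effect of replacing it with a propanoyl group in this assay remains an open question.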